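Chloro position shift on the shared core

The source may report more compounds than this note shows. Statements on the series, on what has been measured and on what is new or still open speak of the compounds shown alone.

Measured so far:
Compound 1 `COc1cc2ncnc(NNC(=S)NC(=O)c3ccccc3)c2cc1OC` gives 3770 nM in a functional assay on KB cells (Homo sapiens) for cytotoxicity, read by MTT assay, with a stated time of 72 h; a lower number here means a stronger inhibitor, a higher number a weaker inhibitor.
Compound 2 `COc1cc2ncnc(NNC(=S)NC(=O)c3cccc(Cl)c3)c2cc1OC` gives 4830 nM in this assay.

For the measured compounds named here, compound 2 stands at the highest of the two numbers recorded; its nearest neighbour is compound 1, and the only recorded step, a 1.3-fold higher number from compound 1 to compound 2 (0.11 log units; within the scatter), lies within the scatter.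

Compound 3 `COc1cc2ncnc(NNC(=S)NC(=O)c3ccc(Cl)cc3)c2cc1OC` differs from compound 2 by 4-chlorophenyl in place of 3-chlorophenyl on a carbonyl carbon. Going by the values given here, no measured pair shows a chloro group moved from one ring position to another; the single step available, a 1.3-fold higher number from compound 1 to compound 2 (0.11 log units; within the scatter), concerns adding chloro rather than relocating it, and it was within the scatter. Among the compounds with values here, with no step of the relevant kind to draw on, the expectation for compound 3 in this assay is a number close to that of compound 2. The expected step is a 1.1-fold lower number from compound 2 to compound 3 (0.03 log units; within the scatter), which is nothing beyond the scatter. Compound 3 is therefore estimated at 4500 nM, with a range from 1800 nM to 11000 nM.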

Compound 3, half-maximal inhibitory concentration: 4590 nM
Beside the measured number, compound 3's estimate is 1.0-fold (0.01 log units) below it; low and high end bracket the measured number.
By their numbers in this assay, from the lowest: compounds 1, 3 and 2 (each within the scatter of the next).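

In this assay, 4-chlorophenyl in place of 3-chlorophenyl on the carbonyl carbon gives the first reading of a relocated chloro (a 1.1-fold lower number from compound 2 to compound 3 (0.02 log units; within the scatter)), so the chloro position among these two compounds leaves the number within the scatter. Chloro in place of hydrogen, now read at a second ring position, gives (a 1.2-fold higher number from compound 1 to compound 3 (0.09 log units; within the scatter)), which means that compound 1, compound 2 and compound 3 all sit within the scatter of one another and the benzoyl ring shows no position sensitivity across these three. No measurement here bears on why these numbers sit together.

As far as these compounds go, whether an amine, a carboxylic acid or a longer chain in place of chloro on this ring would move the number beyond the scatter remains open. Also open, from the compounds shown here alone, is whether this grouping holds on any other cell line.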